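The compounds below may be only part of what the source reports. "The series", "measured", "known", "first", "only" and "open" are said of these compounds alone.

Compound 1 `CCN(CC)c1ccc2cc(C(=O)c3ccc(N4CCN(C(=O)CN5CCN(S(=O)(=O)c6ccc(OC(F)(F)F)cc6)CC5)CC4)cc3)oc2c1`: in an ADME assay on L02 cells (Homo sapiens) for cytotoxicity, read by MTT assay, with a stated time of 48 h (on this read-out lower numbers stand for stronger inhibition and higher numbers for weaker inhibition), compound 1 gives 34700 nM.
Compound 2 `CCN(CC)c1ccc2cc(C(=O)c3ccc(N4CCN(C(=O)CN5CCN(S(=O)(=O)c6ccc(C#N)cc6)CC5)CC4)cc3)oc2c1`: in this assay compound 2 gives 44100 nM.
Compound 3 `CCN(CC)c1ccc2cc(C(=O)c3ccc(N4CCN(C(=O)CN5CCN(S(=O)(=O)c6ccc(F)cc6)CC5)CC4)cc3)oc2c1`: in this assay compound 3 gives 9240 nM.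

Compound 3 stands lowest of the three: the step of a 3.8-fold lower number from compound 1 to compound 3 (0.57 log units; beyond the scatter) and the step of a 4.8-fold lower number from compound 2 to compound 3 (0.68 log units; beyond the scatter) both lie beyond the scatter, while a 1.3-fold higher number from compound 1 to compound 2 (0.10 log units; within the scatter) lies within it. Compound 4 `CCN(CC)c1ccc2cc(C(=O)c3ccc(N4CCN(C(=O)CN5CCN(Cc6ccc(C#N)cc6)CC5)CC4)cc3)oc2c1` has not yet been measured. Its difference from compound 3 is 4-cyanobenzyl in place of (4-fluorophenyl)sulfonyl on an amine nitrogen in a ring. Within the data shown here, no measured step touches the same part of the molecule: the three known steps only swap one group on the aromatic ring attached to the sulfonyl, and each moved the number only modestly. The step here removes that sulfonyl altogether, so the known steps give only weak guidance. The expectation is a 2.2-fold higher number from compound 3 to compound 4 (0.34 log units; beyond the scatter), held with low confidence. Compound 4 is estimated at 20000 nM, with a range from 6000 nM to 60000 nM.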

Compound 4, half-maximal inhibitory concentration: 29600 nM
Compound 4: the middle estimate sits 1.5-fold (0.17 log units) below what was measured, and the stated range covers the measured number.
By their numbers in this assay, from the lowest: compound 3; then compounds 4, 1 and 2 (each within the scatter of the next).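

Measured in this assay with the nitrile kept, replacing the sulfonyl link on this ring nitrogen with a benzyl link gives a 1.5-fold lower number from compound 2 to compound 4 (0.17 log units; within the scatter) so this pair shows that the link can change without a readable shift. The other pair gives a 3.2-fold higher number from compound 3 to compound 4 (0.51 log units; beyond the scatter) but that step also loses the fluoro group, so it cannot separate the two changes. No supporting data here explain either result. Still open, on these data alone, is whether 4-fluorobenzyl on this nitrogen would match compound 3, and how a simple methyl or acetyl group there would behave.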